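The source may hold more compounds than are shown below. What is called first, only, known or untested is meant among the compounds shown, and "the series" means these compounds.

Working notes on the series. Among the compounds with values here, in a functional assay on HeLa cells (Homo sapiens) for inhibition, read by MTT assay, with a stated time of 48 h (on this read-out higher numbers stand for weaker inhibition and lower numbers for stronger inhibition), compound 1 (`COc1ccc(-c2nnnn2-c2cc(OC)c(OC)c(OC)c2)c(O)c1O`) gives 950 nM and holds the lower of the two numbers so far. Compound 2 (`COc1ccc(-c2nnnn2-c2cc(OC)c(OC)c(OC)c2O)c(O)c1`) gives 45000 nM and lies beyond the scatter from compound 1, but the two differ in more than one place, so that gap does not isolate any single change. Compound 3 (`COc1ccc(-c2nnnn2-c2cc(OC)c(OC)c(OC)c2)c(O)c1N`) is compound 1 with amino in place of hydroxy on an aromatic carbon, ortho to a hydroxy group and ortho to a methoxy group. Within the data shown here, no measured pair covers this swap, so the value of compound 1 is the only anchor. A modest rise toward weaker inhibition is expected, and the estimated change is a 2.6-fold higher number from compound 1 to compound 3 (0.42 log units; beyond the scatter) in this assay with wide uncertainty. Compound 3 is estimated at 2500 nM (expected range 600 nM to 12000 nM).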

Compound 3, half-maximal inhibitory concentration: 900 nM
Estimate against measurement, compound 3: 2.8-fold (0.44 log units) above; the measured number falls inside the stated range.
By their numbers in this assay, from the lowest: compounds 3 and 1 (each within the scatter of the next); then compound 2.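

In this assay, within the data shown here, amino in place of hydroxy on an aromatic carbon, ortho to a hydroxy group and ortho to a methoxy group, gives a 1.1-fold lower number from compound 1 to compound 3 (0.02 log units; within the scatter) and is the first step that isolates a single change. At this position, then, the hydroxy group can give way to amino with no difference beyond the scatter, something the gap between compound 1 and compound 2 could not show. Nothing at hand explains why the two groups read alike.

Open, from the compounds shown here alone, is whether this position tolerates larger or differently charged groups, such as an acetamide or a carboxylic acid, or a halogen such as chlorine. Also open, going by these compounds, is whether the same swap would read alike at the remaining hydroxy group of the core of compound 1.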